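The compounds below may be only part of what the source reports. "The series", "measured", "known", "first", "only" and "open" are said of these compounds alone.

Measured compounds:
compound 1, `NCCNC(=O)c1c(O)c2ccccc2n(-c2ccccc2)c1=O`: 10%
compound 2, `Cn1c(=O)c(C(=O)NCCCCCCN)c(O)c2ccccc21`: 8.3%

Of the compounds shown here, two sharing one core have been tested in a functional assay, with a stated time of 60 min, tested at 0.1 mM; a lower number here means a weaker effect, a higher number a stronger effect of the compound at the concentration tested. Compound 1 gives 10% in this assay, and compound 2 gives 8.3%. These two numbers lie within the usual scatter of each other, so nothing can be said about which of the two acts more strongly; both show only a small effect at the concentration tested.

Compound 3, `NCCCCCCNC(=O)c1c(O)c2ccccc2n(-c2ccccc2)c1=O`, has not yet been measured. It differs from compound 2 in one place: phenyl in place of methyl on an aromatic nitrogen. The same phenyl on the same aromatic nitrogen is already present in compound 1, whose value in this assay sits within the scatter of compound 2. On that basis the step from compound 2 to compound 3 is expected to be small, with no change beyond the scatter in either direction, which is what a number 1.7 percentage points higher from compound 2 to compound 3 (within the scatter) expresses. For compound 3 in this assay the expected value is therefore 10%, with a range from 0% to 25%.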

Compound 3, a percentage reported as activity, at one concentration (the size of the read-out at that concentration, not a potency): 17.5%
Estimate against measurement, compound 3: 7.5 percentage points below, within the range that was stated.
By their numbers in this assay, from the lowest: compounds 2, 1 and 3 (each within the scatter of the next).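

In this assay, phenyl and methyl on the aromatic nitrogen can now be compared directly, with the rest of the molecule the same, and this single change reads as a number 9.2 percentage points higher from compound 2 to compound 3 (within the scatter) and so does not separate the two groups, although phenyl is much the larger of them. For the compounds shown here, a second single change can also be read for the first time, with phenyl held on the nitrogen: 4-aminobutyl in place of amino on a saturated chain carbon, two bonds along the chain from an amide-type nitrogen, reads as a number 7.5 percentage points higher from compound 1 to compound 3 (within the scatter) and so does not separate the short chain from the long one either. Nothing available bears on why these two steps have the size they have.

From the compounds shown here alone, it remains open whether a different group on this nitrogen, such as a plain hydrogen, a benzyl group or a phenyl carrying a carboxylic acid, would give a step beyond the scatter, and whether a longer chain ending in an amine would do so at the other end of the molecule. A read-out at a single concentration also shows only the size of the effect at that concentration and leaves open how these compounds would behave at any other.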